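The source may report more compounds than this note shows. Statements on the series, on what has been measured and on what is new or still open speak of the compounds shown alone.

Measured compounds in a functional assay on HCT-116 cells (Homo sapiens) for inhibition, read by sulforhodamine B assay, with a stated time of 72 h; on this read-out lower numbers stand for stronger inhibition and higher numbers for weaker inhibition:

Compound 1 `CC(c1ccc(-c2ccccc2)c(F)c1)c1nnc2n1N=C(c1ccccc1)CS2`: compound 1 gives 9700 nM.
Compound 2 `CC(c1ccc(-c2ccccc2)c(F)c1)c1nnc2n1N=C(c1ccc(C(F)(F)F)cc1)CS2`: compound 2 gives 6100 nM.
Compound 3 `CC(C)Cc1ccc(C(C)c2nnc3n2N=C(c2ccc(C(F)(F)F)cc2)CS3)cc1`: compound 3 gives 6500 nM.

Compound 2 and compound 1 differ by one change, (hydrogen in place of trifluoromethyl on an aromatic carbon), and in this assay this gave a 1.6-fold higher number from compound 2 to compound 1 (0.20 log units; within the scatter). Compound 3 carries the same 4-(trifluoromethyl)phenyl as compound 2 on a different core; the difference between the two cores is not broken down here, and the values of compound 2 and compound 3 lie within the scatter of each other, so nothing is read from that pair.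

Compound 4 `CC(C)Cc1ccc(C(C)c2nnc3n2N=C(c2ccccc2)CS3)cc1` has not been measured. It differs from compound 3 by hydrogen in place of trifluoromethyl on an aromatic carbon, the same change as between compound 2 and compound 1; the change occurs twice in the set, once measured and once not.

From compound 3 to compound 4 a step of a 1.5-fold higher number from compound 3 to compound 4 (0.16 log units; within the scatter) in this assay is expected, resting on the single comparable case, which gave a 1.6-fold higher number from compound 2 to compound 1 (0.20 log units; within the scatter). Compound 4 is therefore estimated at 9500 nM in this assay, with a range from 5000 nM to 19000 nM.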

Compound 4, half-maximal inhibitory concentration: 7600 nM
Estimate against measurement, compound 4: 1.3-fold (0.10 log units) above; the range from low to high includes it.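

In this assay, hydrogen in place of trifluoromethyl on the core of compound 3 gives a 1.2-fold higher number from compound 3 to compound 4 (0.07 log units; within the scatter). Set beside the same change on the core of compound 1, the two steps do not differ: the same change on two cores in this assay, a 1.6-fold higher number (0.20 log units; within the scatter) from compound 2 to compound 1 and a 1.2-fold higher number (0.07 log units; within the scatter) from compound 3 to compound 4, 1.4-fold (0.13 log units) apart, within the scatter of two such steps

Each step lies within the scatter, so the pair shows that this change leaves no readable step on either core and that the two cores agree on that, but it does not show that the change carries a shared step of real size, and two cores support no rule for any other core in the series.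

Open, as far as these compounds go, is whether any other group on this aromatic carbon, para to a large group, such as an amine, a carboxylic acid or a methoxy group, gives a step beyond the scatter. Also open, from the compounds shown here alone, is whether such a group would behave alike on both cores, since trifluoromethyl and hydrogen alone cannot test that.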